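The source may hold more compounds than are shown below. What is called first, only, known or untested is meant among the compounds shown, and "the series" means these compounds.

Compound 1 `Nc1cc(N)c2nc(-c3ccccc3)c(Oc3ccc(Cl)c(Cl)c3)nc2c1` carries the shared core with the two amine groups. In a functional assay on SNB-19 cells (Homo sapiens) for inhibition, read by sulforhodamine B assay, with a stated time of 48 h (a higher number here means that more compound is tolerated, a lower number that less compound is tolerated), compound 1 gives only a limit, < 100000 nM. Compound 2 `COc1ccc(CNc2nc3cc(N)cc(N)c3nc2-c2ccccc2)cc1OC` likewise sits at a limit in this assay, < 100000 nM. Compound 3 `COc1ccc(CNc2nc3cc(N)cc(N)c3nc2-c2ccccc2)cc1` also reaches only a limit, < 100000 nM. The step that the two limits leave unreadable from compound 2 to compound 3 therefore cannot be read, and every measured value sits at the same limit (the limit of < 100000 nM in this assay, at which 3 of the 3 values shown sit). Compound 4 `COc1ccc(Sc2nc3cc(N)cc(N)c3nc2-c2ccccc2)cc1` differs from compound 1 by (4-methoxyphenyl)sulfanyl in place of 3,4-dichlorophenoxy on an aromatic carbon. Going by the values given here, no measured step bears on this change, so no size or direction beyond the scatter is expected in this assay. Compound 4 is estimated at 30000 nM, with a range from 5000 nM to 100000 nM. The expected step that the limit leaves unreadable from compound 1 to compound 4 reflects only the limit shared by the measured compounds.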

Compound 4, concentration lethal to 50% of the cells: < 100000 nM
Compound 4: a limit, no number; the forecaster's own chance of this, stated with the estimate: 40%; the middle value lies beyond the limit too.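

Compound 1 and compound 4 both give only a limit in this assay, so no step can be read between them: the limit of < 100000 nM in this assay, at which 4 of the 4 values shown sit.
The compounds shown leave open the actual values and whether (4-methoxyphenyl)sulfanyl in place of 3,4-dichlorophenoxy changes anything.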